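The source may hold more compounds than are shown below. What is called first, only, known or untested is meant among the compounds shown, and "the series" means these compounds.

Compound 1 `N#CC1=C(N)Oc2c(N)cc3nc4ccccc4nc3c2C12C(=O)N(Cc1cnnn1-c1ccc([N+](=O)[O-])cc1)c1ccccc12`: > 50000 nM
Compound 2 `CCc1cccc(CC)c1-n1nncc1CN1C(=O)C2(C(C#N)=C(N)Oc3c(N)cc4nc5ccccc5nc4c32)c2ccccc21`: > 50000 nM

Two compounds built on the same large core differ only in the group carried on an aromatic nitrogen of a five-membered aromatic ring with 3 nitrogen. In an ADME assay on HUVEC cells (Homo sapiens) for antiproliferative activity, read by MTT assay, with a stated time of 48 h (a higher number here means a weaker inhibitor, a lower number a stronger inhibitor), compound 1 reaches only the limit of the assay, > 50000 nM, and not a number. In this assay compound 2 likewise reaches only a limit, > 50000 nM. The step that the two limits leave unreadable from compound 1 to compound 2 therefore has no readable size, since both values sit at the limit of > 50000 nM in this assay, at which 2 of the 2 values shown sit. Compound 2 thus stands at the limit of this assay, with no measured number of its own to build on.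

Compound 3 `N#CC1=C(N)Oc2c(N)cc3nc4ccccc4nc3c2C12C(=O)N(Cc1cnnn1-c1c(F)cccc1F)c1ccccc12` differs from compound 2 in one place: 2,6-difluorophenyl in place of 2,6-diethylphenyl on an aromatic nitrogen. For the measured compounds named here, the only measured step, a step that the two limits leave unreadable from compound 1 to compound 2, also exchanged the group on that nitrogen and gives nothing that can be read. The step that the limit leaves unreadable from compound 2 to compound 3 is therefore expected to show no direction beyond the scatter in this assay. Compound 3 is estimated to sit at 80000 nM, within 30000 nM to 250000 nM, and most likely to come back again as a limit rather than a number.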

Compound 3, half-maximal inhibitory concentration: > 50000 nM
Compound 3 was reported as a limit; the forecaster's own chance of this, stated with the estimate: 85%; the middle value is on the limit's open side.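

In this assay compound 3 also gives only a limit, not a number, so the steps to compound 3 from compound 1 and compound 2 cannot be read: the limit of > 50000 nM in this assay, at which 3 of the 3 values shown sit. Going by these compounds, what remains open is whether any group on that aromatic nitrogen of the shared core would give a measurable value in this assay, and how far compound 1, compound 2 and compound 3 truly differ.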